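The source may report more compounds than this note shows. Statements on the series, on what has been measured and on what is new or still open speak of the compounds shown alone.

Of the compounds shown here, three sharing one core have been tested in a functional assay on MOLM-13 cells (Homo sapiens) for antiproliferative activity (a lower number here means a stronger inhibitor, a higher number a weaker inhibitor), differing only in one group on an aromatic carbon. Compound 2 `Cc1c(-c2ccc(-c3ccccc3F)cc2)nc2ccc(F)cc2c1-c1nnn[nH]1`, which carries 1H-tetrazol-5-yl there, reads > 3000 nM, and this is a limit of the assay, not a number. Compound 1 `Cc1c(-c2ccc(-c3ccccc3F)cc2)nc2ccc(F)cc2c1C(F)F`, with difluoromethyl at that place, reads > 3000 nM, which is also a limit. Between these two there is a step that the two limits leave unreadable from compound 1 to compound 2. Compound 3 `Cc1c(-c2ccc(-c3ccccc3F)cc2)nc2ccc(F)cc2c1C(N)=O`, with carbamoyl instead, gives 128 nM.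

Compound 4 `Cc1c(-c2ccc(-c3ccccc3F)cc2)nc2ccc(F)cc2c1C(=O)NS(C)(=O)=O` has not yet been measured. In it, (methylsulfonyl)carbamoyl replaces 1H-tetrazol-5-yl on the same aromatic carbon, opposite the ring nitrogen ((methylsulfonyl)carbamoyl in place of 1H-tetrazol-5-yl on an aromatic carbon). For the measured compounds named here, two measured steps bear on this change: an at least 23-fold lower number from compound 2 to compound 3 (1.36 log units; beyond the scatter), and an at least 23-fold lower number from compound 1 to compound 3 (1.36 log units; beyond the scatter). Both are large, and both end at the carbamoyl group of compound 3, which the entering group contains with methylsulfonyl added. Compound 4 is therefore expected to recover only part of the gain seen with compound 3 at 128 nM. Compound 4 may well stay at the limit of this assay. The expected change, modest and toward a lower number, is an at least 1.5-fold lower number from compound 2 to compound 4 (0.17 log units; that floor lies within the scatter). For compound 4 the estimated value is 2000 nM, with an expected range from 400 nM to 6000 nM.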

Compound 4, half-maximal inhibitory concentration: 300 nM
Beside the measured number, compound 4's estimate is 6.7-fold (0.82 log units) above it, outside the stated range (below it).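

In this assay, adding methylsulfonyl to the amide-type nitrogen at this position carries only a modest cost, a 2.3-fold higher number from compound 3 to compound 4 (0.37 log units; beyond the scatter), so the activity seen with carbamoyl does not depend on that nitrogen staying unsubstituted. The (methylsulfonyl)carbamoyl group also stands well clear of the groups that sit at the limit, with an at least 10-fold lower number from compound 2 to compound 4 (1.00 log units; beyond the scatter) and an at least 10-fold lower number from compound 1 to compound 4 (1.00 log units; beyond the scatter), even though it matches 1H-tetrazol-5-yl in its counts of hydrogen-bond donors and acceptors and differs from it in having no ring. These two steps are floors rather than sizes, because each starts from a value that is a limit of the assay and not a number: the limit of > 3000 nM in this assay, at which 2 of the 4 values shown sit.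

The compounds shown leave open whether other groups on the same nitrogen, such as a methyl, an acetyl or a phenylsulfonyl group, would keep this activity, and whether a carboxylic acid or an amine on the same aromatic carbon would do so. They also cannot say how compound 1 and compound 2 compare with each other, since that step lies between two limits and cannot be read.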